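This account rests on a few compounds, and the source may have more. Where it says the series, first, only, none or still open, it means among the compounds named here.

In a functional assay on SNB-75 cells (Homo sapiens) for inhibition, read by sulforhodamine B assay, with a stated time of 48 h, tested at 10 uM (a lower number here means less inhibition of growth, a higher number more inhibition of growth at the concentration tested), compound 3 (`C/C(=N/O)c1ccc(NC(=O)Cn2nc(C(F)(F)F)nc2N)cc1`) gives 14.8%. This lies within the usual scatter of compound 1 (`CC(=O)c1ccc(NC(=O)Cn2nc(-c3ccc(Cl)cc3)nc2N)cc1`), which gives 6.47%, so the two cannot be told apart on these numbers. Compound 2 (`COc1ccc(-c2nc3sc(-c4ccccc4)cn3n2)cc1`) gives 34%, clearly more inhibition of growth than compound 3 shows.

Compound 4 (`C/C(=N/O)c1ccc(NC(=O)Cn2nc(-c3ccccc3)nc2N)cc1`) has not yet been measured. It differs from compound 3 in one place, with phenyl in place of trifluoromethyl on an aromatic carbon.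

Among the compounds with values here, no two measured compounds differ in only one place, so no direct step is available as a guide, and any expectation is rough. Compound 1 also carries a six-membered aromatic ring of carbon only at that place, though it differs elsewhere too, and compound 1 reaches just 6.47%. No change beyond the scatter is therefore expected, and the estimated a number 1.8 percentage points lower from compound 3 to compound 4 (within the scatter) is small and slightly downward. For compound 4 the estimated value is 13%, within an expected range of 2% to 30%.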

Compound 4, percent growth inhibition at one concentration: 22.5%
Estimate against measurement, compound 4: 9.5 percentage points below; measured number inside the range.
By their numbers in this assay, from the lowest: compounds 1, 3 and 4 (each within the scatter of the next, the first and the last beyond it); then compound 2.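

In this assay, within the data shown here, putting phenyl in place of trifluoromethyl on the aromatic carbon between two ring nitrogen atoms gives the first direct reading at this position (a number 7.7 percentage points higher from compound 3 to compound 4 (within the scatter)). The position therefore accepts a six-membered aromatic ring of carbon only, with 6 heavy atoms in place of 4, and these numbers cannot separate the two compounds in growth inhibition. No measured property bears on this result, so it stands as an observation without an explanation.

As far as these compounds go, whether an amine, a carboxylic acid or a longer alkyl chain on this carbon would move the number beyond the scatter remains open. Also open, from the compounds shown here alone, is whether a hydroxyl group or a nitrile on the new phenyl ring would do so.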